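Replacing methoxy with fluoro in a high-scoring compound

A few compounds are considered here, and "the series" means these few. Any claim that something is new, unique, unknown or untested is made for them only; others in the source may bear on it.

In a functional assay on HL-60 cells (Homo sapiens) for inhibition, read by CCK-8 assay, with a stated time of 48 h, tested at 20 uM (a lower number here means less inhibition of growth, a higher number more inhibition of growth at the concentration tested), compound 1 `COc1ccc(S(=O)(=O)Oc2ccccc2/C=C(\C#N)C(=O)Nc2nnc(-c3cccs3)s2)cc1` gives 67%, while compound 2 `COc1ccc(S(=O)(=O)Oc2ccccc2/C=C(\C#N)C(=O)Nc2nnc(Cc3cccc4ccccc34)s2)cc1` gives 98%, the higher of the two numbers. Compound 3 `N#C/C(=C\c1ccccc1OS(=O)(=O)c1ccc(F)cc1)C(=O)Nc1nnc(Cc2cccc3ccccc23)s1` differs from compound 2 in one place: fluoro in place of methoxy on an aromatic carbon. Going by the values given here, the only measured step, a number 31 percentage points higher from compound 1 to compound 2 (beyond the scatter), is large but concerns a different group, so no measured step tests this change directly. The expected step is a number 6 percentage points lower from compound 2 to compound 3 (within the scatter), which is estimated to stay within the scatter. For compound 3 the estimate is 92%, with an expected range of 72% to 100%.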

Compound 3, percent growth inhibition at one concentration: 12%
Beside the measured number, compound 3's estimate is 80 percentage points above it; the measured number lies below the stated range.
By their numbers in this assay, from the lowest: compound 3; then compound 1; then compound 2.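

In this assay fluoro in place of methoxy gives a number 86 percentage points lower from compound 2 to compound 3 (beyond the scatter) and so shows that this position is highly sensitive: one small substituent swap on the sulfonyl-bound ring removes most of the growth inhibition. Going by these compounds alone, the earlier step showed only that the group on an aromatic carbon elsewhere in the molecule matters. Nothing available explains the loss.

Going by these compounds, whether an ethoxy or dimethylamino group here would keep the inhibition stays open. So does whether fluoro would cost as much in compound 1, which carries thiophen-2-yl.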